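A few compounds are considered here, and "the series" means these few. Any claim that something is new, unique, unknown or untested is made for them only; others in the source may bear on it.

Measured so far in an ADME assay on the whole organism for cytotoxicity, with Artemia salina as the target, with a stated time of 24 h; on this read-out higher numbers stand for an effect only at larger amounts of compound and lower numbers for an effect already at smaller amounts:
- compound 1, `COc1cccc(/C=C/C(=O)c2ccccc2NC(=O)NS(=O)(=O)c2ccc(C)cc2)c1`: compound 1 gives 23.2 ug/mL
- compound 2, `CCc1cc(/C=C/C(=O)c2ccccc2NC(=O)NS(=O)(=O)c2ccc(C)cc2)cc(OC)c1OC`: compound 2 gives 19.2 ug/mL
- compound 3, `Cc1ccc(S(=O)(=O)NC(=O)Nc2ccccc2C(=O)/C=C/c2ccccc2Cl)cc1`: compound 3 gives 12.8 ug/mL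

The three numbers sit close together. Compound 3 lies at one edge of the range, but a 1.8-fold lower number from compound 1 to compound 3 (0.26 log units; within the scatter) and a 1.5-fold lower number from compound 2 to compound 3 (0.18 log units; within the scatter) are both within the scatter, as is a 1.2-fold lower number from compound 1 to compound 2 (0.08 log units; within the scatter). Every one of these steps exchanges the aryl group on the double-bonded chain carbon bound to a double-bonded chain carbon, and none of them moved this assay beyond its scatter.

Compound 4, `Cc1ccc(S(=O)(=O)NC(=O)Nc2ccccc2C(=O)/C=C/c2ccncc2)cc1`, is the next exchange at the same place: pyridin-4-yl in place of 2-chlorophenyl on a double-bonded chain carbon bound to a double-bonded chain carbon. For the measured compounds named here, this brings a ring with a hetero atom, which no measured compound carries, so the three steps bear on it only as a sign that this position has so far been tolerant. On that basis the step is expected to be a 1.2-fold higher number from compound 3 to compound 4 (0.07 log units; within the scatter), that is, no shift beyond the scatter in either direction. Compound 4 is therefore estimated at 15 ug/mL, with a range of 6 ug/mL to 35 ug/mL.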

Compound 4, concentration for half-maximal effect: 16.8 ug/mL
Compound 4: middle estimate off by 1.1-fold (0.05 log units), on the low side, and the stated range covers the measured number.
By their numbers in this assay, from the lowest: compounds 3, 4, 2 and 1 (each within the scatter of the next).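

In this assay pyridin-4-yl, the only ring shown here with a hetero atom, stays within the scatter of all three phenyl-bearing compounds, with a 1.3-fold higher number from compound 3 to compound 4 (0.12 log units; within the scatter) and a 1.1-fold lower number from compound 2 to compound 4 (0.06 log units; within the scatter) and a 1.4-fold lower number from compound 1 to compound 4 (0.14 log units; within the scatter). The tolerance seen so far on the double-bonded chain carbon bound to a double-bonded chain carbon therefore extends from substituted phenyl groups to a ring that brings in nitrogen, and no order can be drawn among the four compounds. No measured evidence bears on why the read-out stays within so narrow a range.

Going by these compounds, all four groups at this place are six-membered aromatic rings, so a saturated ring such as piperidin-4-yl or an open alkyl chain remains untested in these data. Also open, on these data alone, is whether a phenyl ring carrying a carboxylic acid or an amine would stay within the same range.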